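The source may hold more compounds than are shown below. What is called first, only, known or untested is meant among the compounds shown, and "the series" means these compounds.

Of the compounds shown here, three built on a shared core have been tested in a functional assay on MOLT-4 cells (Homo sapiens); on this read-out higher numbers stand for weaker inhibition and lower numbers for stronger inhibition. Compound 1 `NC(=O)c1cn([C@@H]2O[C@H](CO)[C@@H](O)[C@H]2O)nn1` carries a carbamoyl group on an aromatic carbon of that core. In this assay compound 1 reaches only the limit of the assay, > 200000 nM. Compound 2 `OCc1cn([C@@H]2O[C@H](CO)[C@@H](O)[C@H]2O)nn1` carries a hydroxymethyl group in the same place. In this assay compound 2 likewise stops at the limit, > 200000 nM. Compound 3 `OC[C@H]1O[C@@H](n2cc(-c3ccccn3)nn2)[C@H](O)[C@@H]1O` carries a pyridin-2-yl group and is the only one of the three with a true number: in this assay compound 3 gives 170000 nM, so it stands as the one readable point among three. The step that the two limits leave unreadable from compound 1 to compound 2 cannot be read, as both ends sit at the limit of > 200000 nM in this assay, at which 2 of the 3 values shown sit. The steps of an at least 1.1-fold lower number from compound 1 to compound 3 (0.07 log units; that floor lies within the scatter) and an at least 1.1-fold lower number from compound 2 to compound 3 (0.07 log units; that floor lies within the scatter) are each only a floor, and that floor lies within the scatter.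

Compound 4 `OC[C@H]1O[C@@H](n2cc(-c3ccc(F)cc3)nn2)[C@H](O)[C@@H]1O` has not yet been measured. It differs from compound 3 by 4-fluorophenyl in place of pyridin-2-yl on an aromatic carbon. Among the measured compounds shown here, no measured step exchanges one six-membered ring for another, so the only guidance is that entering pyridin-2-yl in compound 3 shifted the number no further than an at least 1.1-fold lower number from compound 1 to compound 3 (0.07 log units; that floor lies within the scatter) and an at least 1.1-fold lower number from compound 2 to compound 3 (0.07 log units; that floor lies within the scatter), both within the scatter. The expected step is therefore a 1.1-fold lower number from compound 3 to compound 4 (0.05 log units; within the scatter), a change not beyond the scatter. Compound 4 is expected to give about 150000 nM, somewhere from 60000 nM to 350000 nM, with a real chance that only a limit is reported.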

Compound 4, half-maximal inhibitory concentration: 171000 nM
Compound 4: the middle estimate sits 1.1-fold (0.06 log units) below what was measured; measured number inside the range.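

In this assay, among the compounds shown here, the exchange of rings on this aromatic carbon gives a 1.0-fold higher number from compound 3 to compound 4 (0.00 log units; within the scatter), the first step at this position with a true number at both ends. A six-membered ring with one nitrogen and a hydrogen-bond acceptor and a carbon-only ring carrying fluorine therefore read alike here, so neither the ring nitrogen nor the fluorine separates these two compounds. The comparisons with the carbamoyl and hydroxymethyl groups remain an at least 1.1-fold lower number from compound 1 to compound 4 (0.06 log units; that floor lies within the scatter) and an at least 1.1-fold lower number from compound 2 to compound 4 (0.06 log units; that floor lies within the scatter), each only a floor, because both starting points stand at a limit: the limit of > 200000 nM in this assay, at which 2 of the 4 values shown sit.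

From the compounds shown here alone, it remains open whether an unsubstituted phenyl, or a methoxy group or an amine on that ring in place of the fluorine, would move the number beyond the scatter. Going by these compounds, it is equally open whether a different kind of group on this aromatic carbon, such as a carboxylic acid or a longer chain, or any change elsewhere on the shared core, would bring a stronger inhibition than the ring compounds show.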